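Cyclobutyl in place of ethyl on a ring amine nitrogen

This account rests on a few compounds, and the source may have more. Where it says the series, first, only, none or still open, it means among the compounds named here.

Measured so far in a functional assay on A-375 cells (Homo sapiens) for inhibition, read by MTT assay, with a stated time of 4 days (on this read-out higher numbers stand for weaker inhibition and lower numbers for stronger inhibition), are two compounds:
- compound 1 `c1cc(-c2c(-c3ccncc3)nn3c(-c4ccc(CN5C[C@@H]6C[C@H]5CO6)cc4)ccnc23)c2cn[nH]c2c1` gives 945 nM
- compound 2 `CCN1C[C@@H]2C[C@H]1CN2c1cc(F)c(-c2ccnc3c(-c4cccc5[nH]ncc45)c(-c4ccncc4)nn23)c(F)c1` gives 56 nM

Of the two, compound 2 has the lower number and so the stronger inhibition, and its gap to compound 1 lies beyond the scatter. Next comes compound 3 `Fc1cc(N2C[C@@H]3C[C@H]2CN3C2CCC2)cc(F)c1-c1ccnc2c(-c3cccc4[nH]ncc34)c(-c3ccncc3)nn12`, with cyclobutyl in place of ethyl on an amine nitrogen in a ring on the frame of compound 2. Among the measured compounds shown here, no measured pair covers this change. The estimated 1.1-fold higher number from compound 2 to compound 3 (0.03 log units; within the scatter) in this assay is expected to stay within the scatter, with no direction favoured. Expected for compound 3 is 60 nM with a range from 25 nM to 150 nM as the working estimate.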

Compound 3, half-maximal inhibitory concentration: 78 nM
For compound 3 the middle estimate is 1.3-fold (0.11 log units) below the measured one; the range from low to high includes it.
By their numbers in this assay, from the lowest: compounds 2 and 3 (each within the scatter of the next); then compound 1.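

In this assay the step to cyclobutyl gives a 1.4-fold higher number from compound 2 to compound 3 (0.14 log units; within the scatter) and so leaves compound 2 and compound 3 indistinguishable. This amine nitrogen in a ring therefore carries a four-membered non-aromatic ring of carbon only as well as it carries ethyl, at least on this frame. Nothing at hand gives a reason for this tolerance.

Still open, on these data alone, is whether a hydrogen on this nitrogen, an acetyl group or a longer chain ending in a hydroxyl would hold the number equally well.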